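Replacing 2-chlorophenyl with 2-phenylethenyl in compound 3

The compounds below may be only part of what the source reports. "The series", "measured", "known", "first", "only" and "open" are said of these compounds alone.

Three compounds have been measured in an ADME assay on cells (Rhabdomyosarcoma cell, Homo sapiens) for cytotoxicity, read by MTT assay, with a stated time of 72 h; a higher number here means that more compound is tolerated, a lower number that less compound is tolerated:

compound 1, `Fc1ccc(/C=N/c2sc3c(c2-c2nc4ccccc4s2)CCCC3)cc1`, gives 230 ug/mL
compound 2, `Clc1ccc(/C=N/c2sc3c(c2-c2nc4ccccc4s2)CCCC3)cc1`, gives 367 ug/mL
compound 3, `Clc1ccccc1/C=N/c1sc2c(c1-c1nc3ccccc3s1)CCCC2`, gives 332 ug/mL

Compound 3 sits second highest of these three numbers. Its nearest neighbour is compound 2, reached by a 1.1-fold lower number from compound 2 to compound 3 (0.04 log units; within the scatter), and the furthest is compound 1, reached by a 1.4-fold higher number from compound 1 to compound 3 (0.16 log units; within the scatter); both steps are within the scatter, so the three compounds cannot be told apart on these numbers.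

Compound 4, `C(=C/c1ccccc1)\C=N\c1sc2c(c1-c1nc3ccccc3s1)CCCC2`, has not yet been measured. It differs from compound 3 in one place: 2-phenylethenyl in place of 2-chlorophenyl on a carbon with a double bond to nitrogen. Every measured step changes the same part of the molecule, the group on the carbon with a double bond to nitrogen, and none moved the number beyond the scatter: a 1.6-fold higher number from compound 1 to compound 2 (0.20 log units; within the scatter), a 1.4-fold higher number from compound 1 to compound 3 (0.16 log units; within the scatter) and a 1.1-fold lower number from compound 2 to compound 3 (0.04 log units; within the scatter). None of them, however, replaces the whole aromatic group with a chain bearing a double bond outside aromatic rings, so the present change is larger than any already tested. On the evidence of the three flat steps, the expected step is a 1.0-fold lower number from compound 3 to compound 4 (0.02 log units; within the scatter), that is, no movement beyond the scatter. Compound 4 is therefore estimated at 320 ug/mL, with a range from 150 ug/mL to 650 ug/mL.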

Compound 4, half-maximal cytotoxic concentration: 207 ug/mL
The estimate for compound 4 lay 1.5-fold (0.19 log units) above the measured number; the range from low to high includes it.
By their numbers in this assay, from the lowest: compounds 4, 1, 3 and 2 (each within the scatter of the next).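

In this assay, the change at the carbon with a double bond to nitrogen now goes beyond swapping one halogen-bearing phenyl group for another, yet all three new steps stay within the scatter (a 1.6-fold lower number from compound 3 to compound 4 (0.21 log units; within the scatter); a 1.8-fold lower number from compound 2 to compound 4 (0.25 log units; within the scatter); a 1.1-fold lower number from compound 1 to compound 4 (0.05 log units; within the scatter)). With 2-phenylethenyl, which brings a double bond outside aromatic rings, this position therefore still gives no readable difference among the four compounds shown. No measurement is available that could explain this result.

From the compounds shown here alone, it remains open whether a group without an aromatic ring at this place, such as an amine, a carboxylic acid or a longer saturated chain, would move the number beyond the scatter. The compounds also leave open whether changes elsewhere on the shared core would do so.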